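This account rests on a few compounds, and the source may have more. Where it says the series, first, only, none or still open, it means among the compounds named here.

Compound 1 `O=C(NC(=S)N1CCc2cccc(OCc3ccccc3)c21)c1ccccc1` gives only a limit of the assay in an ADME assay on Huh-7 cells (Homo sapiens) for cytotoxicity (on this read-out lower numbers stand for higher toxicity in this test and higher numbers for lower toxicity in this test), namely > 50000 nM. Among the measured compounds shown here, compound 2 `O=C(NC(=S)N1CCc2c(OCCCCCOc3ccc(Cl)cc3)cccc21)c1cccc([N+](=O)[O-])c1` is the only compound with a measured number in this assay, giving 12100 nM. Compound 3 `O=C(NC(=S)N1CCc2c(OCCCCCOc3ccc(Cl)cc3)cccc21)c1ccc(C(F)(F)F)cc1` differs from compound 2 in a single place: 4-(trifluoromethyl)phenyl in place of 3-nitrophenyl on a carbonyl carbon. For the measured compounds named here, no measured pair of compounds shows what such a change does in this assay, so the step from compound 2 to compound 3 is expected to stay within the usual scatter, in no particular direction, at a 1.2-fold higher number from compound 2 to compound 3 (0.09 log units; within the scatter). Compound 3 is therefore estimated at 15000 nM, with a range from 5000 nM to 50000 nM.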

Compound 3, half-maximal cytotoxic concentration: 32700 nM
For compound 3 the middle estimate is 2.2-fold (0.34 log units) below the measured one; measured number inside the range.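

At the carbonyl carbon, the group carried there can shift the read-out in this assay with everything else held fixed: 4-(trifluoromethyl)phenyl in place of 3-nitrophenyl gives a 2.7-fold higher number from compound 2 to compound 3 (0.43 log units; beyond the scatter), which means lower toxicity in this test. Among the compounds shown here, this is the first step measured at this place. For the compounds shown here, the scale for higher numbers ends at a limit, the one reported for compound 1: the limit of > 50000 nM in this assay, at which 1 of the 3 values shown sits.

Compound 3 changes both the group on the phenyl ring and where it sits, so the two effects cannot be separated. Going by these compounds, how an amine or a carboxylic acid on that ring would behave also stays open.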